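The source may hold more compounds than are shown below. What is called first, only, known or untested is meant among the compounds shown, and "the series" means these compounds.

In a physicochemical assay for lipophilicity, at pH 7.4 (a lower number here means a more polar compound, a higher number a more lipophilic compound), compound 1 (`CCCCCCC/C=C/c1c(C)[nH]c2ccccc2c1=O`) gives 4.26 and compound 2 (`COc1ccc2[nH]c(C)c(Cc3ccccc3)c(=O)c2c1`) gives 2.53 on the readings so far. Compound 3 (`CCc1c(C)[nH]c2cc(OC)c(F)cc2c1=O`) gives 1.2 and stands lowest of the three, nearest to compound 2 and furthest from compound 1, with both gaps beyond the scatter. Compound 4 (`CCc1c(C)[nH]c2cc(OC)c(Cl)cc2c1=O`) is still unmeasured and differs from compound 3 in one place (chloro in place of fluoro on an aromatic carbon): chloro in place of fluoro on an aromatic carbon, ortho to a methoxy group. Among the measured compounds shown here, no measured pair isolates this exchange, so the expectation rests on the structural change alone. A modest rise in this assay is expected, an estimated a number 0.50 log units higher from compound 3 to compound 4 (beyond the scatter) that would lie just beyond the scatter. The estimated value for compound 4 is 1.7 with an expected range of 1.3 to 2.2 for this measurement.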

Compound 4, distribution coefficient: 2.43
Beside the measured number, compound 4's estimate is 0.73 log units below it, outside the stated range (above it).
By their numbers in this assay, from the lowest: compound 3; then compounds 4 and 2 (each within the scatter of the next); then compound 1.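

Chloro in place of fluoro on an aromatic carbon, ortho to a methoxy group, gives a number 1.23 log units higher from compound 3 to compound 4 (beyond the scatter) in this assay and is the only single-place step in the series so far. A change of one heavy atom at this position is therefore enough to produce a large step on this core. No measured data on hand explain the size of this step. As far as these compounds go, whether bromo or a nitrile at this position would give a step of similar size stays open. From the compounds shown here alone, whether the exchange behaves alike with a group other than ethyl on the core also stays open.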